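From pyridin-4-yl to 3-methylphenyl on a shared core

This account rests on a few compounds, and the source may have more. Where it says the series, first, only, none or still open, it means among the compounds named here.

Compound 1 (`C(=C/c1nn2c(-c3ccncc3)nnc2s1)\c1ccco1`) gives 66500 nM
Compound 2 (`COc1ccccc1-c1nnc2sc(/C=C/c3ccco3)nn12`) gives 1070 nM

In a functional assay on MV4-11 cells (Homo sapiens) for antiproliferative activity, read by resazurin assay, with a stated time of 72 h (a lower number here means a stronger inhibitor, a higher number a weaker inhibitor), compound 1 gives 66500 nM as the higher of the two numbers, which marks the weaker result, and its gap to compound 2 lies beyond the scatter. Still unmeasured is compound 3 (`Cc1cccc(-c2nnc3sc(/C=C/c4ccco4)nn23)c1`). It differs from compound 1 in one place: 3-methylphenyl in place of pyridin-4-yl on an aromatic carbon. A six-membered aromatic ring with one hetero atom leaves, and a six-membered aromatic ring of carbon only enters. Among the compounds with values here, no measured pair shows this swap on its own, so the size of the step can only be estimated. Within the data shown here, compound 3 is expected to land closer to compound 2 because compound 2 gives 1070 nM as the only other measured number, which makes this a cautious guess. The estimated step in this assay is a large fall beyond the scatter (a 27-fold lower number from compound 1 to compound 3 (1.42 log units; beyond the scatter)). The estimate for compound 3 is 2500 nM with an expected range (600 nM to 12000 nM).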

Compound 3, half-maximal inhibitory concentration: 124000 nM
Compound 3: the middle estimate sits 50-fold (1.70 log units) below what was measured, outside the stated range (above it).
By their numbers in this assay, from the lowest: compound 2; then compounds 1 and 3 (each within the scatter of the next).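

Across this assay, putting 3-methylphenyl in place of pyridin-4-yl on the aromatic carbon between two ring nitrogen atoms gives a step that cannot be told apart from the usual scatter (a 1.9-fold higher number from compound 1 to compound 3 (0.27 log units; within the scatter)). So at this position, a six-membered aromatic ring of carbon only bearing a methyl group and a six-membered aromatic ring with one hetero atom read alike, and removing the ring nitrogen does not by itself bring the number near that of compound 2 (1070 nM). No measurement offered here explains why these two groups read alike.

The three compounds do not show which feature of the group in compound 2 sets it apart from the groups in compound 1 and compound 3, and they cannot separate the effect of the methyl group from that of the ring nitrogen. Also open, going by these compounds, is how an unsubstituted phenyl ring, or a phenyl ring carrying an amine or a carboxylic acid, would read at this same position on the shared core.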